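Phenyl for thiophen-3-yl across two chlorophenyl analogues

This account rests on a few compounds, and the source may have more. Where it says the series, first, only, none or still open, it means among the compounds named here.

Three compounds on a shared core are measured. In a functional assay on T47D cells (Homo sapiens) for cytotoxicity, read by CCK-8 assay and cell counting, with stated times of 4 h and 2 days (a lower number here means a stronger inhibitor, a higher number a weaker inhibitor), compound 1 `Oc1cccc(-c2cc(-c3ccccc3Cl)cc(-c3ccsc3)n2)c1` gives 680 nM. In this assay compound 2 `Oc1cccc(-c2cc(-c3ccccc3Cl)cc(-c3ccccc3)n2)c1` gives 680 nM, and compound 3 `Oc1cccc(-c2cc(-c3cccc(Cl)c3)cc(-c3ccsc3)n2)c1` gives 680 nM. The change from compound 1 to compound 2, (phenyl in place of thiophen-3-yl on an aromatic carbon), made no change at the digits printed from compound 1 to compound 2 (within the scatter). The two cores differ by 3-chlorophenyl in place of 2-chlorophenyl on an aromatic carbon, which gave no change at the digits printed from compound 1 to compound 3 (within the scatter).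

Compound 4 `Oc1cccc(-c2cc(-c3cccc(Cl)c3)cc(-c3ccccc3)n2)c1` is not yet measured. It carries the same kind of change as compound 2, namely (phenyl in place of thiophen-3-yl on an aromatic carbon); around the place, the leaving group in compound 1 stands meta to a 2-chlorophenyl group, whereas in compound 3 it stands meta to a 3-chlorophenyl group. From compound 3 to compound 4 a step of no change at the digits printed from compound 3 to compound 4 (within the scatter) is expected, because no change at the digits printed from compound 1 to compound 2 (within the scatter) and because no change at the digits printed from compound 1 to compound 3 (within the scatter). Compound 4 is therefore estimated at 680 nM, expected between 340 nM and 1400 nM.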

Compound 4, half-maximal inhibitory concentration: 680 nM
Beside the measured number, compound 4's estimate shows no gap at the digits printed; measured number inside the range.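

In this assay, phenyl in place of thiophen-3-yl gave no change at the digits printed from compound 3 to compound 4 (within the scatter), matching the same change on the 2-chlorophenyl core: the same change on two cores in this assay, no change at the digits printed (within the scatter) from compound 1 to compound 2 and no change at the digits printed (within the scatter) from compound 3 to compound 4, 1.0-fold (0.00 log units) apart, within the scatter of two such steps

Likewise, 3-chlorophenyl in place of 2-chlorophenyl gave no change at the digits printed from compound 2 to compound 4 (within the scatter), matching its step on the thiophen-3-yl core: the same change on two cores in this assay, no change at the digits printed (within the scatter) from compound 1 to compound 3 and no change at the digits printed (within the scatter) from compound 2 to compound 4, 1.0-fold (0.00 log units) apart, within the scatter of two such steps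

Each change therefore carries between these two cores, but only as a null step; with all four compounds level, this does not show that a change that moves the value would carry in the same way.

Open, going by these compounds, is whether any change at these places moves the value in this assay. An amine or a carboxylic acid in place of the phenyl, or a methoxy in place of the hydroxy on the 3-hydroxyphenyl group, would test this.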